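Amide in place of amine on a macrocyclic enone

This account rests on a few compounds, and the source may have more. Where it says the series, first, only, none or still open, it means among the compounds named here.

Compounds measured in a functional assay on MCF7 cells (Homo sapiens) for antiproliferative activity, read by MTT assay, with a stated time of 48 h; on this read-out lower numbers stand for stronger inhibition and higher numbers for weaker inhibition:
compound 1 `CC(=O)OC/C1=C/C[C@](C)(CCC=C(C)C)/C=C/[C@@H](OC(=O)C=C(C)C)[C@](C)(OC(C)=O)/C=C/C1=O`, 3990 nM
compound 2 `CC(=O)O[C@]1(C)/C=C/C(=O)/C(CO)=C\C[C@](C)(CCC=C(C)C)/C=C/[C@H]1OC(=O)C=C(C)C`, 2320 nM
compound 3 `CCN(CC)C/C1=C/C[C@](C)(CCC=C(C)C)/C=C/[C@@H](OC(=O)C=C(C)C)[C@](C)(O)/C=C/C1=O`, 130 nM

Compound 3 stands lowest of the three numbers. Compound 2 is the nearest to it, and compound 1 the furthest; both gaps lie beyond the scatter. Compound 3 differs from compound 1 and from compound 2 in two places at once, so no single step in this set explains its position. For the measured compounds named here, the one step with a single change, a 1.7-fold lower number from compound 1 to compound 2 (0.24 log units; within the scatter), concerns the substituent on the same double-bonded ring carbon but moves between an acetate and a free hydroxymethyl, not between an amine and an amide.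

Compound 4 `CC(C)=CCC[C@]1(C)/C=C/[C@@H](OC(=O)C=C(C)C)[C@](C)(O)/C=C/C(=O)/C(C(=O)N(C)C)=C\C1` is the next member. Its change from compound 3 is dimethylcarbamoyl in place of (diethylamino)methyl on a double-bonded ring carbon. Going by the values given here, no measured step bears directly on this exchange, since the amine of compound 3 has no counterpart elsewhere. Among the compounds with values here, the only precedent at this ring position is small. As far as these compounds go, compound 3 differs from the other two measured compounds in two places at once, and the separate shares of those two changes are unknown. Compound 4 is therefore expected to lose ground against compound 3, by a step of about a 5.4-fold higher number from compound 3 to compound 4 (0.73 log units; beyond the scatter), with wide uncertainty. Compound 4 is estimated at 700 nM, within a range from 200 nM to 3000 nM.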

Compound 4, half-maximal inhibitory concentration: 3670 nM
Beside the measured number, compound 4's estimate is 5.2-fold (0.72 log units) below it, outside the stated range (above it).
By their numbers in this assay, from the lowest: compound 3; then compounds 2, 4 and 1 (each within the scatter of the next).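

In this assay, for the compounds shown here, dimethylcarbamoyl in place of (diethylamino)methyl on this double-bonded ring carbon gives a 28-fold higher number from compound 3 to compound 4 (1.45 log units; beyond the scatter), a large step, whereas the only earlier single change at this carbon, a 1.7-fold lower number from compound 1 to compound 2 (0.24 log units; within the scatter), stayed within the scatter. The number at this position can therefore move widely with the substituent, even though the two groups exchanged here carry the same counts of hydrogen-bond donors and acceptors and neither has a net charge, so those counts do not separate them. Nothing measured in this set accounts for the size of the step.

The compounds shown leave open whether the step goes with the carbonyl of the amide or with the methyl groups on nitrogen taking the place of ethyl groups, as both change together in this one exchange. A (dimethylamino)methyl group or a diethylcarbamoyl group on the same ring carbon would pull these two changes apart, and a carboxylic acid or a morpholine-bearing methyl group there would show how far the result extends beyond this pair.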